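The source may report more compounds than this note shows. Statements on the series, on what has been measured and on what is new or still open speak of the compounds shown alone.

Compound 1, `Cc1ccc(/C=C/C(=O)c2ccc(NC(=S)Nc3ccc(Cl)cc3)cc2)cc1`: 13.1 umol/kg
Compound 2, `Cc1ccc(/C=C/C(=O)c2ccc(NC(=O)Nc3ccc(Cl)cc3)cc2)cc1`: 39.7 umol/kg

In a functional assay on the whole organism (Abdomen, strain Swiss) with Mus musculus as the target, with a stated time of 30 min (on this read-out higher numbers stand for an effect only at larger amounts of compound and lower numbers for an effect already at smaller amounts), compound 2 gives 39.7 umol/kg, the higher of the two numbers, while compound 1 gives 13.1 umol/kg, a gap beyond the usual scatter. Compound 3, `O=C(Nc1ccc(Cl)cc1)Nc1ccc(C(=O)/C=C/c2ccc(Cl)cc2)cc1`, has not yet been measured. It differs from compound 2 in one place: chloro in place of methyl on an aromatic carbon. For the measured compounds named here, no measured pair shows this exchange of chloro for methyl, so the data give no direction for it. The step expected is a 1.0-fold higher number from compound 2 to compound 3 (0.00 log units; within the scatter), which amounts to none beyond the scatter. Compound 3 is therefore estimated at 40 umol/kg, with a range from 20 umol/kg to 80 umol/kg.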

Compound 3, dose for 50% inhibition: 45.4 umol/kg
For compound 3 the middle estimate is 1.1-fold (0.05 log units) below the measured one; low and high end bracket the measured number.
By their numbers in this assay, from the lowest: compound 1; then compounds 2 and 3 (each within the scatter of the next).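

Going from 4-methylphenyl to 4-chlorophenyl gives a 1.1-fold higher number from compound 2 to compound 3 (0.06 log units; within the scatter) in this assay. For the compounds shown here, this is the first view of any exchange at this position, and with the rest of compound 2 held fixed, chloro and methyl cannot be told apart on this read-out. No data shown here offer an explanation for this result. The compounds shown leave open whether an amine, a carboxylic acid or a methoxy group at this position would shift the number. They also leave open whether the same exchange would read alike on the core of compound 1.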